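Aryl swap on the double-bonded chain: compound 4

The source may report more compounds than this note shows. Statements on the series, on what has been measured and on what is new or still open speak of the compounds shown alone.

Going by the values given here, compound 2 `COc1ccccc1/C=C/C[C@H]1C[C@@H]([C@@H](O)c2ccccc2)CO[C@@H]1c1ccccc1` stands lowest of the three numbers measured so far: in a functional assay on HL-60 cells (Homo sapiens) for cytotoxicity, read by WST assay, with a stated time of 48 h (on this read-out higher numbers stand for weaker inhibition and lower numbers for stronger inhibition), compound 2 gives 10100 nM. Compound 1 `COc1ccc(/C=C/C[C@@H]2C[C@@H]([C@@H](O)c3ccc(OC)c(OC)c3)CO[C@H]2c2ccc(OC)c(OC)c2)cc1OC` gives 26000 nM in this assay, and compound 3 `COc1ccc(/C=C/C[C@H]2C[C@H]([C@H](O)c3ccc(OC)c(OC)c3)CO[C@@H]2c2ccc(OC)c(OC)c2)cc1OC` gives 23500 nM. The gaps from compound 2 to compound 3 and from compound 2 to compound 1 both lie beyond the scatter. Compound 1 and compound 3 are related by a 1.1-fold lower number from compound 1 to compound 3 (0.04 log units; within the scatter), a step that stays within the scatter, as the fact that compounds 1 and 3 differ only in the configuration as drawn notes.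

Compound 4 `O[C@@H](c1ccccc1)[C@H]1CO[C@H](c2ccccc2)[C@@H](C/C=C/c2ccc(F)cc2)C1` is reached from compound 2 by 4-fluorophenyl in place of 2-methoxyphenyl on a double-bonded chain carbon bound to a double-bonded chain carbon. Among the compounds with values here, no measured pair in this set changes the aryl group on the double-bonded chain; the only measured step, between compound 1 and compound 3, concerns configuration alone and lies within the scatter, so it offers no direction for the present change. All three measured values sit in a narrow band, and compound 2 is the nearest starting point. For compound 4 the expected step is a 1.0-fold lower number from compound 2 to compound 4 (0.00 log units; within the scatter), taken as no step beyond the scatter. Compound 4 is therefore estimated at 10000 nM in this assay, with a range from 4000 nM to 25000 nM.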

Compound 4, half-maximal inhibitory concentration: 8110 nM
Compound 4: middle estimate off by 1.2-fold (0.09 log units), on the high side; the range from low to high includes it.
By their numbers in this assay, from the lowest: compounds 4 and 2 (each within the scatter of the next); then compounds 3 and 1 (each within the scatter of the next).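

In this assay, going by these compounds alone, the change of aryl group on the double-bonded chain gives a 1.2-fold lower number from compound 2 to compound 4 (0.10 log units; within the scatter), the first step that reads this position. Placing 4-fluorophenyl where 2-methoxyphenyl stood, on a double-bonded chain carbon bound to a double-bonded chain carbon, removes the hydrogen-bond acceptor of the leaving group, yet no shift beyond the scatter goes with it, at least for this one pair. The only other step in the series concerns configuration alone, so nothing shown accounts for this outcome or bears on this aryl change.

Open is whether an amine or a carboxylic acid on this aryl ring would move the number beyond the scatter, since the aryl groups shown at this position carry only methoxy or fluorine. Also open, going by these compounds, is whether 4-fluorophenyl in this place would behave the same way on the core of compound 1 or compound 3, and whether any aryl group at this position can bring the number beyond the scatter of compound 2 at all.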